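The source may hold more compounds than are shown below. What is called first, only, known or untested is meant among the compounds shown, and "the series" means these compounds.

Measured so far:
Compound 1, `Cc1cccc(Oc2ccnc(N3CCC[C@H]3C(=O)NCc3cccnc3)n2)c1`: 16%
Compound 2, `Cc1cccc(Oc2ccnc(N3CCC[C@H]3C(=O)NCCCn3ccnc3)n2)c1`: 7%

In an assay on isolated protein for inhibition of ribosomal protein S6 kinase beta-1 (Homo sapiens), read by HTRF, tested at 10 uM (a higher number here means more inhibition at the concentration tested (going by the name of the read-out), a lower number less inhibition), compound 2 stands beside compound 1, both at weak inhibition; the step of a number 9 percentage points lower from compound 1 to compound 2 (within the scatter) lies within the scatter, so the two numbers cannot be told apart.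

Compound 3, `COC(=O)C(CO)NC(=O)[C@@H]1CCCN1c1nccc(Oc2cccc(C)c2)n1`, has not yet been measured in this assay. It differs from compound 2 by 2-hydroxy-1-(methoxycarbonyl)ethyl in place of 3-(1H-imidazol-1-yl)propyl on an amide-type nitrogen. For the measured compounds named here, the one measured step bears on this change, since it also exchanged the group on the same amide-type nitrogen: a number 9 percentage points lower from compound 1 to compound 2 (within the scatter), a step within the scatter. A second exchange at the same place is therefore expected to move the number little. The expected step is a number 3 percentage points higher from compound 2 to compound 3 (within the scatter), no larger than the scatter. Compound 3 is thus estimated at 10%, with a range from 0% to 25%.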

Compound 3, a percentage reported as inhibition, at one concentration (the size of the read-out at that concentration, not a potency): 5%
Beside the measured number, compound 3's estimate is 5 percentage points above it, and the stated range covers the measured number.
By their numbers in this assay, from the lowest: compounds 3, 2 and 1 (each within the scatter of the next, the first and the last beyond it).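

In this assay, putting the ring-free 2-hydroxy-1-(methoxycarbonyl)ethyl on the amide-type nitrogen in place of 3-(1H-imidazol-1-yl)propyl gives a number 2 percentage points lower from compound 2 to compound 3 (within the scatter), so at this place a group with no ring cannot be told apart from one with a five-membered aromatic ring. Set against the (pyridin-3-yl)methyl of compound 1, the same group gives a number 11 percentage points lower from compound 1 to compound 3 (beyond the scatter), the first difference at this nitrogen that exceeds the scatter, though only a modest one, and compound 2 remains within the scatter of both neighbours. No measurement at hand accounts for these numbers.

All three compounds have been read only at the one concentration tested, so these numbers say nothing beyond the inhibition at that concentration. As far as these compounds go, whether a carboxylic acid in place of the methoxycarbonyl, or a pyridin-3-yl ring on a longer chain, would raise the number stays open.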